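Replacing the dichlorophenyl group of compound 3

The compounds below may be only part of what the source reports. "The series", "measured", "known", "first", "only" and "open" are said of these compounds alone.

compound 1 `COc1ccc2cc([C@H](C)c3nnc(SCc4ccc(C)cc4)n3-c3ccc(F)cc3)ccc2c1`: 44300 nM
compound 2 `COc1ccc2cc([C@H](C)c3nnc(SCc4ccc(F)cc4)n3-c3ccc(F)cc3)ccc2c1`: 60200 nM
compound 3 `COc1ccc2cc([C@H](C)c3nnc(SCc4c(Cl)cccc4Cl)n3-c3ccc(F)cc3)ccc2c1`: 12300 nM

In a functional assay on DU-145 cells (Homo sapiens) for cytotoxicity, read by MTT assay (a higher number here means a weaker inhibitor, a lower number a stronger inhibitor), compound 3 gives 12300 nM, the lowest number of the three and so the strongest inhibitor here. Compound 4 `COc1cccc(CSc2nnc([C@@H](C)c3ccc4cc(OC)ccc4c3)n2-c2ccc(F)cc2)c1` differs from it by 3-methoxyphenyl in place of 2,6-dichlorophenyl on a saturated chain carbon bound to a sulfur. Two measured steps brought in the 2,6-dichlorophenyl: a 3.6-fold lower number from compound 1 to compound 3 (0.56 log units; beyond the scatter) and a 4.9-fold lower number from compound 2 to compound 3 (0.69 log units; beyond the scatter). The third, a 1.4-fold higher number from compound 1 to compound 2 (0.13 log units; within the scatter), changed little. Among the measured compounds shown here, no measured compound carries 3-methoxyphenyl, so this is only a reading by analogy. Losing the 2,6-dichlorophenyl is expected to undo a step of that modest size, an estimated 3.3-fold higher number from compound 3 to compound 4 (0.51 log units; beyond the scatter). For compound 4 the expected value is 40000 nM, within an estimated range of 15000 nM to 100000 nM.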

Compound 4, half-maximal inhibitory concentration: 19200 nM
The estimate for compound 4 lay 2.1-fold (0.32 log units) above the measured number, within the range that was stated.
By their numbers in this assay, from the lowest: compounds 3 and 4 (each within the scatter of the next); then compounds 1 and 2 (each within the scatter of the next).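

Moving from 2,6-dichlorophenyl to 3-methoxyphenyl in this assay gives a 1.6-fold higher number from compound 3 to compound 4 (0.19 log units; within the scatter), so at this position the low number does not depend on chlorine. The new group also separates from the 4-substituted rings, with a 3.1-fold lower number from compound 2 to compound 4 (0.50 log units; beyond the scatter) and a 2.3-fold lower number from compound 1 to compound 4 (0.36 log units; beyond the scatter), so 4-fluorophenyl and 4-methylphenyl both stand apart from these two differently substituted rings. Nothing available explains these differences.

Going by these compounds, it remains open whether 4-methoxyphenyl would behave like 4-fluorophenyl and 4-methylphenyl or like 3-methoxyphenyl. On these data alone, the effect of an unsubstituted phenyl or a ring-bound amine at this position also remains open.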